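Aryl substituent change on the shared core, agonist activity

This account rests on a few compounds, and the source may have more. Where it says the series, first, only, none or still open, it means among the compounds named here.

In a functional assay on CHO cells for agonist activity at Alpha-1B adrenergic receptor (Homo sapiens), read by FLIPR and calcium flux (a lower number here means that less compound is needed, a higher number that more compound is needed for the effect), compound 1 `CCS(=O)(=O)Nc1cccc2c1CCC2c1ncc[nH]1` gives only the limit > 10000 nM and no number. Compound 2 `CS(=O)(=O)Nc1cccc2c1CCCC2c1ncc[nH]1` likewise stops at the limit > 10000 nM; > 10000 nM; > 10000 nM (3 entries) in this assay. Compound 3 `Cn1ccc(-c2cccc3c2CCC3c2ncc[nH]2)n1` also reaches only the limit > 10000 nM. Compound 1 therefore stands at the limit, as every measured compound here does: the limit of > 10000 nM in this assay, at which 2 of the 3 values shown sit. Compound 4 `c1cc(-c2ccn[nH]2)c2c(c1)C(c1ncc[nH]1)CC2` carries the change (1H-pyrazol-5-yl in place of (ethylsulfonyl)amino on an aromatic carbon). Among the compounds with values here, the single measured step that bears on it, a step that the two limits leave unreadable from compound 1 to compound 3, gives no readable size, so no direction is known. The step of a number no higher from compound 1 to compound 4 (the limit leaves the size open) is expected to be none beyond the scatter, with a further limit the most likely outcome. Compound 4 is estimated at 10000 nM, between 2000 nM and 50000 nM.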

Compound 4, half-maximal effective concentration: 600 nM
Compound 4: the middle estimate sits 17-fold (1.22 log units) above what was measured, and the stated range ends above it.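

Within the data shown here, on this aromatic carbon, 1H-pyrazol-5-yl in place of (ethylsulfonyl)amino gives the first number (an at least 16-fold lower number from compound 1 to compound 4 (1.22 log units; beyond the scatter)). A five-membered aromatic ring with 2 hetero atoms does not by itself give that number, as the 1-methyl-1H-pyrazol-3-yl of compound 3 shows (an at least 16-fold lower number from compound 3 to compound 4 (1.22 log units; beyond the scatter)). All other compounds stay at a limit: the limit of > 10000 nM in this assay, at which 2 of the 4 values shown sit.

Compound 3 and compound 4 differ in both the methyl group and the ring attachment, and these two changes remain unseparated. On these data alone, how a 1-methyl-1H-pyrazol-5-yl, a triazole or an amine would read on this carbon remains open.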